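From compound 2 to compound 4: one group exchanged

The source may hold more compounds than are shown below. What is called first, only, known or untested is meant among the compounds shown, and "the series" means these compounds.

In a functional assay on KB cells (Homo sapiens) for cytotoxicity, read by MTT assay, with a stated time of 48 h (on this read-out lower numbers stand for stronger inhibition and higher numbers for weaker inhibition), compound 1 `CCn1cc(-c2nc3ccccc3[nH]2)c(=O)c2cc(F)c(N3CCNCC3)nc21` gives 2000 nM, compound 3 `CCn1cc(-c2nc3ccccc3o2)c(=O)c2cc(F)c(Cl)cc21` gives 10200 nM, and compound 2 `CCn1cc(-c2nc3ccccc3[nH]2)c(=O)c2cc(F)c(N3CCNC(C)C3)c(F)c21` gives 19100 nM. Compound 2 thus lies within the scatter of compound 3, and beyond the scatter on the weaker side of compound 1. Compound 4 `CCn1cc(-c2nc3ccccc3s2)c(=O)c2cc(F)c(N3CCNC(C)C3)c(F)c21` carries 1,3-benzothiazol-2-yl in place of the 1H-benzimidazol-2-yl of compound 2, on an aromatic carbon: 1,3-benzothiazol-2-yl in place of 1H-benzimidazol-2-yl on an aromatic carbon. Among the measured compounds shown here, no measured pair isolates this exchange, since the three measured compounds differ from one another in more than one place. The estimated change in this assay is a 1.6-fold lower number from compound 2 to compound 4 (0.20 log units; within the scatter), which is not expected to go beyond the scatter. For compound 4 the expected value is 12000 nM, with an estimated range of 4000 nM to 35000 nM.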

Compound 4, half-maximal inhibitory concentration: 24300 nM
Compound 4: middle estimate off by 2.0-fold (0.31 log units), on the low side; the range from low to high includes it.
By their numbers in this assay, from the lowest: compound 1; then compounds 3, 2 and 4 (each within the scatter of the next, the first and the last beyond it).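

In this assay, among the compounds shown here, 1,3-benzothiazol-2-yl in place of 1H-benzimidazol-2-yl gives a 1.3-fold higher number from compound 2 to compound 4 (0.10 log units; within the scatter), the first step in the set that isolates a single place. On this aromatic carbon, then, a group with no hydrogen-bond donor stands within the scatter of the group that has one, at least on the core of compound 2. No measurement available explains this result. From the compounds shown here alone, whether an amine or a carboxylic acid on this carbon would stay within the scatter remains open. So does whether the same exchange would give a similar step on the core of compound 1.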